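Swapping bromo for methoxy on a benzimidazole acid

This account rests on a few compounds, and the source may have more. Where it says the series, first, only, none or still open, it means among the compounds named here.

Compound 2 `CCCCc1nc2ccccc2n1Cc1ccc(C(=O)O)cc1Br` has, in an in vivo functional assay on the whole organism for antagonist activity at Type-2 angiotensin II receptor (Rattus norvegicus) (on this read-out lower numbers stand for an effect already at smaller amounts and higher numbers for an effect only at larger amounts of compound), the value 11.1 mg/kg; that is the lowest of the two numbers measured, yet compound 1 `CCCCc1nc2ccccc2n1Cc1ccc(C(=O)O)cc1`, with 12.6 mg/kg, sits within the scatter of it. Within the data shown here, the only measured step touching this part of the molecule, a 1.1-fold lower number from compound 1 to compound 2 (0.06 log units; within the scatter), therefore shows no real effect. Compound 3 `CCCCc1nc2ccccc2n1Cc1ccc(C(=O)O)cc1OC` differs from compound 2 by methoxy in place of bromo on an aromatic carbon. Among the measured compounds shown here, no measured step covers methoxy in place of bromo, so for compound 3 the expected step is a 1.1-fold higher number from compound 2 to compound 3 (0.03 log units; within the scatter), nothing beyond the scatter. Compound 3 is thus estimated at 12 mg/kg, within 6 mg/kg to 25 mg/kg.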

Compound 3, dose for half-maximal effect: 16.1 mg/kg
Estimate against measurement, compound 3: 1.3-fold (0.13 log units) below; low and high end bracket the measured number.
By their numbers in this assay, from the lowest: compounds 2, 1 and 3 (each within the scatter of the next).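

In this assay methoxy at this place, ortho to a large group and meta to a carboxy group, gives no real shift from bromo (a 1.5-fold higher number from compound 2 to compound 3 (0.16 log units; within the scatter)) or from hydrogen (a 1.3-fold higher number from compound 1 to compound 3 (0.11 log units; within the scatter)). Hydrogen, bromo and methoxy therefore cannot be told apart here, even though methoxy adds a hydrogen-bond acceptor that bromo lacks. No measured evidence offers an explanation for this result. As far as these compounds go, whether an amine, a hydroxyl or a longer chain at this place would change the number beyond the scatter stays open.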